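A Methyl Added Beside the Ring Oxygen of Compound 2

This account rests on a few compounds, and the source may have more. Where it says the series, first, only, none or still open, it means among the compounds named here.

Measured so far:
compound 1, `O=C1NC(=O)/C(=C/C2=Cc3ccccc3OC2)S1`: > 200000 nM
compound 2, `O=C1NC(=O)/C(=C/C2=Cc3cc(Br)ccc3OC2)S1`: 56500 nM
compound 3, `O=C1NC(=O)/C(=C/C2=Cc3cc(Br)ccc3OC2)N1`: 35900 nM

Of the compounds shown here, three sharing one core have been tested in an ADME assay on NIH3T3 cells (Mus musculus) for antiproliferative activity, read by MTT assay, with a stated time of 72 h; a lower number here means a stronger inhibitor, a higher number a weaker inhibitor. Compound 1 gives only a limit of the assay, > 200000 nM, and no number (the limit of > 200000 nM in this assay, at which 1 of the 3 values shown sits). Compound 2 gives 56500 nM in this assay. The number for compound 3, 35900 nM, lies within the usual scatter of the number for compound 2, so these two cannot be told apart. Among the values that are numbers, compound 2 therefore sits with compound 3 at the same level. Going by the values given here, the only measured step, an at least 3.5-fold lower number from compound 1 to compound 2 (0.54 log units; beyond the scatter), comes from a bromine added to the aromatic ring.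

Compound 4, `CC1Oc2ccc(Br)cc2C=C1/C=C1\SC(=O)NC1=O`, differs from compound 2 by methyl in place of hydrogen on a saturated ring carbon. Among the compounds with values here, no measured step touches a saturated ring carbon, so nothing seen so far points to a change in this assay beyond the scatter in either direction. Compound 4 is therefore expected to give about 50000 nM, with a range from 20000 nM to 150000 nM. The estimated step of a 1.1-fold lower number from compound 2 to compound 4 (0.05 log units; within the scatter) is expected to stay within the scatter.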

Compound 4, half-maximal inhibitory concentration: 56200 nM
Compound 4: the middle estimate sits 1.1-fold (0.05 log units) below what was measured; low and high end bracket the measured number.
By their numbers in this assay, from the lowest: compounds 3, 4 and 2 (each within the scatter of the next). At a limit, above all of these: compound 1.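

In this assay, methyl in place of hydrogen on the saturated ring carbon next to the ring oxygen gives a 1.0-fold lower number from compound 2 to compound 4 (0.00 log units; within the scatter), so this change cannot be told from no change at all. The earlier compounds shown here showed a measured step only on an aromatic carbon, whereas this result shows that this saturated ring carbon can carry a methyl with no shift that the assay can separate from the scatter. Nothing available bears on the reason for this result.

The compounds shown leave open whether a larger or differently built group at this position, such as an amine, a carboxylic acid or a longer chain, would move the number beyond the scatter. They also leave open whether the same methyl would behave alike on compound 3.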